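Phenyl to Dimethoxyphenyl on a Weakly Active Scaffold

The source may hold more compounds than are shown below. What is called first, only, known or untested is meant among the compounds shown, and "the series" means these compounds.

Compound 3 `Cc1nc(-c2ccccc2)sc1C(=O)CSc1nc(-c2ccccc2)c(C#N)c(=O)[nH]1` gives 92.1% in a functional assay on U-87MG ATCC cells for antiproliferative activity against U-87 MG (Homo sapiens), read by MTT assay, with a stated time of 48 h, tested at 5 uM (a higher number here means a weaker effect of the compound at the concentration tested, a lower number a stronger effect), the second highest of three numbers. Compound 1 `COc1ccc(-c2nc(SCC(=O)c3sc(-c4ccccc4)nc3C)[nH]c(=O)c2C#N)cc1` gives 97.3% in this assay, within the scatter of compound 3, while compound 2 `COc1ccc(-c2nc(C)c(C(=O)CSc3nc(-c4ccc(OC)c(OC)c4)c(C#N)c(=O)[nH]3)s2)cc1` gives 81.2%, beyond it. Compound 4 `COc1ccc(-c2nc(SCC(=O)c3sc(-c4ccccc4)nc3C)[nH]c(=O)c2C#N)cc1OC` differs from compound 3 by 3,4-dimethoxyphenyl in place of phenyl on an aromatic carbon. For the measured compounds named here, the one measured step at that position, a number 5.2 percentage points lower from compound 1 to compound 3 (within the scatter), stayed within the scatter. Compound 2 carries the same 3,4-dimethoxyphenyl but differs from compound 4 elsewhere, so its value is only a loose guide. Compound 4 is therefore expected to show a number 3.1 percentage points lower from compound 3 to compound 4 (within the scatter), no step beyond the scatter. The estimate for compound 4 is 89%, between 76% and 100%.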

Compound 4, a percentage reported as activity, at one concentration (the size of the read-out at that concentration, not a potency): 80.8%
The estimate for compound 4 lay 8.2 percentage points above the measured number; the measured number falls inside the stated range.
By their numbers in this assay, from the lowest: compounds 4 and 2 (each within the scatter of the next); then compounds 3 and 1 (each within the scatter of the next).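

In this assay, for the compounds shown here, 3,4-dimethoxyphenyl at this position gives the first step here beyond the scatter, a number 11.3 percentage points lower from compound 3 to compound 4 (beyond the scatter). The second methoxy alone also goes beyond it, a number 16.5 percentage points lower from compound 1 to compound 4 (beyond the scatter). By contrast, hydrogen in place of methoxy on the other aromatic ring stays within the scatter, a number 0.4 percentage points lower from compound 2 to compound 4 (within the scatter), and that change reads alike on two cores: the same change on two cores in this assay, a number 5.2 percentage points lower (within the scatter) from compound 1 to compound 3 and a number 0.4 percentage points lower (within the scatter) from compound 2 to compound 4, 4.8 percentage points apart, within the scatter of two such steps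

As far as these compounds go, whether an amine or a carboxylic acid on this phenyl would lower the number further remains open. With one concentration per compound, these numbers speak only of a stronger or weaker effect at that concentration.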